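Ring-carbon substituents and cytotoxicity across the series

This account rests on a few compounds, and the source may have more. Where it says the series, first, only, none or still open, it means among the compounds named here.

Compound 3 `O=C1O[C@@H](CN2CCC(O)CC2)CN1c1ccc(-n2cc(-c3ccccn3)cn2)c(F)c1` carries hydroxy on a saturated ring carbon. In an ADME assay on HEK293-A cells (Homo sapiens) for cytotoxicity, read by MTT assay, with a stated time of 48 h (on this read-out lower numbers stand for stronger inhibition and higher numbers for weaker inhibition), compound 3 gives > 400 ug/mL, which is a limit of the assay and not a number. Compound 1 `O=C1O[C@@H](CN2CCCCC2)CN1c1ccc(-n2cc(-c3ccccn3)cn2)c(F)c1` gives > 400 ug/mL in this assay, likewise a limit. Compound 2 `COC(=O)CC1CCN(C[C@H]2CN(c3ccc(-n4cc(-c5ccccn5)cn4)c(F)c3)C(=O)O2)CC1` gives 224 ug/mL in this assay. Two of the three values therefore sit at the limit of > 400 ug/mL in this assay, at which 2 of the 3 values shown sit. Of the measured steps, an at least 1.7-fold lower number from compound 1 to compound 2 (0.25 log units; that floor lies within the scatter); a step that the two limits leave unreadable from compound 1 to compound 3; an at least 1.7-fold higher number from compound 2 to compound 3 (0.25 log units; that floor lies within the scatter). Compound 4 `O=C1O[C@@H](CN2CCC(c3ccc(F)cc3)CC2)CN1c1ccc(-n2cc(-c3ccccn3)cn2)c(F)c1` differs from compound 3 by 4-fluorophenyl in place of hydroxy on a saturated ring carbon. Since the steps seen at this carbon are within the scatter or unreadable, for compound 4 in this assay a step of an at least 1.6-fold lower number from compound 3 to compound 4 (0.20 log units; that floor lies within the scatter) is expected, not beyond the scatter. Compound 4 is estimated at 250 ug/mL, with a range from 100 ug/mL to 400 ug/mL.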

Compound 4, half-maximal inhibitory concentration: > 400 ug/mL
Compound 4 gave a limit, no number (the forecaster's own chance of this, stated with the estimate: 40%); middle value at least 1.6-fold (0.20 log units) from the limit.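

In this assay compound 4 also ends at a limit of the assay and not a number, so a large aromatic group on this carbon now joins hydroxy and hydrogen at the same ceiling: the limit of > 400 ug/mL in this assay, at which 3 of the 4 values shown sit. The steps from compound 1 and compound 3 to this compound cannot be read. Against the only number in the set, the result is an at least 1.7-fold higher number from compound 2 to compound 4 (0.25 log units; that floor lies within the scatter), so (methoxycarbonyl)methyl is not separated from 4-fluorophenyl beyond the scatter.

From the compounds shown here alone, whether an amine or a carboxylic acid on this carbon would give a number under the limit stays open. So does whether any group here shifts the value beyond the scatter.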